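Swapping the saturated ring for pyridine on the shared core

The source may hold more compounds than are shown below. What is called first, only, known or untested is meant among the compounds shown, and "the series" means these compounds.

Compound 1 `Cc1ccc(-c2nc(N)c3cc(CCc4ccccc4)sc3n2)o1` and compound 2 `Cc1ccc(-c2nc(N)c3cc(Cc4ccccc4Cl)sc3n2)o1` differ only on the saturated chain carbon bound to an aromatic carbon. In a functional assay on CHO-K1 cells for antagonist activity at adenosine receptor A1 (Homo sapiens), read by a beta-galactosidase reporter and cAMP accumulation, with stated times of 15 min and 6 h (on this read-out lower numbers stand for stronger inhibition and higher numbers for weaker inhibition), compound 1 gives 2780 nM, while compound 2 gives 26.1 nM. For the measured compounds named here, the only measured step is a 110-fold lower number from compound 1 to compound 2 (2.03 log units; beyond the scatter). Compound 3 `Nc1nc(C2CCCO2)nc2sc(Cc3ccccc3)cc12` gives 2950 nM in this assay; its number sits within the scatter of compound 1 and far from compound 2. Compound 4 `Nc1nc(-c2ccncc2)nc2sc(Cc3ccccc3)cc12` differs from compound 3 by pyridin-4-yl in place of oxolan-2-yl on an aromatic carbon. Going by the values given here, no measured pair alters this position, and the single known step concerns a different place, so the data give no guide to size or direction here. Compound 4 is therefore expected near compound 3, at 2000 nM with a range of 300 nM to 12000 nM in this assay. That estimate means an expected step of a 1.5-fold lower number from compound 3 to compound 4 (0.17 log units; within the scatter), one that need not exceed the scatter.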

Compound 4, inhibition constant: 812 nM
Compound 4: middle estimate off by 2.5-fold (0.39 log units), on the high side; low and high end bracket the measured number.
By their numbers in this assay, from the lowest: compound 2; then compound 4; then compounds 1 and 3 (each within the scatter of the next).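

At this position, an aromatic carbon between two ring nitrogen atoms, the substituent does affect the number in this assay: pyridin-4-yl in place of oxolan-2-yl gives a 3.6-fold lower number from compound 3 to compound 4 (0.56 log units; beyond the scatter) on the shared core. For the compounds shown here, this is the first measured change here, and it is modest, far smaller than the only other step measured. Nothing available accounts for this step.

The compounds shown leave open whether a plain phenyl ring or a pyridin-3-yl group would match pyridin-4-yl here. They also leave open whether an open chain such as an ethyl group would fall nearer oxolan-2-yl.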